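The compounds below may be only part of what the source reports. "The series", "measured", "known", "first", "only" and "open" are said of these compounds alone.

Compound 2 `C=C(Br)C(=O)Nc1cccc(-c2cn3nc(-c4ccc(OCC)cc4)sc3n2)c1` gives 1100 nM in a functional assay on FM3A cells (Mus musculus) for inhibition, read by cell counting, with a stated time of 2 days (a lower number here means a stronger inhibitor, a higher number a weaker inhibitor), the lowest of the two numbers shown. Compound 1 `CCOc1ccc(-c2nn3cc(-c4cccc(N)c4)nc3s2)cc1` gives >= 250000 nM in this assay, a limit of the assay and not a number. The step of an at least 220-fold lower number from compound 1 to compound 2 (2.35 log units; beyond the scatter) is large. Compound 3 `Nc1cccc(-c2cn3c(-c4ccc(Cl)cc4)csc3n2)c1`, carrying chloro together with the free amine, gives 11000 nM in this assay. Compound 4 `C=C(Br)C(=O)Nc1cccc(-c2cn3nc(-c4ccc(Cl)cc4)sc3n2)c1` differs from compound 2 by chloro in place of ethoxy on an aromatic carbon. For the measured compounds named here, no measured step changes this group alone, since compound 1 and compound 3 both keep the free amine rather than the (1-bromoethenyl)carbonyl group, so their values show only where those two compounds stand. A step of about a 1.1-fold lower number from compound 2 to compound 4 (0.04 log units; within the scatter) is expected, within the scatter. Compound 4 is estimated at 1000 nM, between 300 nM and 3500 nM.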

Compound 4, half-maximal inhibitory concentration: 2000 nM
For compound 4 the middle estimate is 2.0-fold (0.30 log units) below the measured one; the measured number falls inside the stated range.
By their numbers in this assay, from the lowest: compounds 2 and 4 (each within the scatter of the next); then compound 3. At a limit, above all of these: compound 1.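

In this assay, for the compounds shown here, the only direct reading of this aromatic carbon is a 1.8-fold higher number from compound 2 to compound 4 (0.26 log units; within the scatter), so with the (1-bromoethenyl)carbonyl group present, 4-ethoxyphenyl and 4-chlorophenyl cannot be told apart. Compound 1 and compound 3 differ in more than this group and could not show that. Nothing measured here accounts for the two groups reading alike.

Only these two groups are shown at this place. On these data alone, whether a hydroxyl, an amine, a carboxylic acid or a longer alkoxy chain on this carbon would also read alike stays open.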